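The source may hold more compounds than are shown below. What is called first, only, known or untested is meant among the compounds shown, and "the series" means these compounds.

Measured compounds and values in an assay on CHO cells for displacement of a labelled ligand from adenosine receptor A3 (Homo sapiens), read by scintillation counting, tested at 1 uM; a lower number here means less inhibition, a higher number more inhibition at the concentration tested (going by the name of the read-out):
- compound 1, `CC(C)c1nc(N)c2nn(-c3ccccc3)cc2n1`, gives 11%
- compound 2, `Nc1nc(CCc2ccccc2)nc2cn(-c3ccccc3)nc12`, gives 17%

Compound 2 stands highest of the two numbers in this assay, but only by a number 6 percentage points higher from compound 1 to compound 2 (within the scatter), a step that stays within the scatter; on the numbers shown, the two compounds are not separated. Next in the series is compound 3, `Nc1nc(CCCc2ccccc2O)nc2cn(-c3ccccc3)nc12`, not yet measured in this assay.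

Compound 3 differs from compound 2 by one change: 2-hydroxybenzyl in place of phenyl on a saturated chain carbon, two bonds along the chain from an aromatic carbon. Among the measured steps, only the one from compound 1 to compound 2 touches the same chain position, and it concerned the length of the chain rather than the ring at its end; it was a number 6 percentage points higher from compound 1 to compound 2 (within the scatter). For the measured compounds named here, no measured step carries a hydroxyl or a longer chain, so nothing in the data sets the direction for the present change. Given that the one step at this position stayed within the scatter, compound 3 is expected to sit near compound 2, with a step of about a number 3 percentage points higher from compound 2 to compound 3 (within the scatter). Compound 3 is therefore estimated at 20% in this assay, with a likely range from 5% to 40%.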

Compound 3, a percentage reported as inhibition, at one concentration (the size of the read-out at that concentration, not a potency): 36%
Estimate against measurement, compound 3: 16 percentage points below; low and high end bracket the measured number.
By their numbers in this assay, from the lowest: compounds 1 and 2 (each within the scatter of the next); then compound 3.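

In this assay, for the compounds shown here, this position turns out to respond: 2-hydroxybenzyl in place of phenyl on a saturated chain carbon, two bonds along the chain from an aromatic carbon, gives a number 19 percentage points higher from compound 2 to compound 3 (beyond the scatter) and is the first step to clear the usual scatter. The earlier step touching this chain, a number 6 percentage points higher from compound 1 to compound 2 (within the scatter), did not separate its two compounds, so only the present change shows that the number can move with what is carried at this place. The entering group brings oxygen and a hydrogen-bond donor and acceptor that phenyl lacks, and it also lengthens the chain within the same single step, and nothing at hand bears on why the number rises.

Left open is which part of the change carries the step: the same longer chain ending in an unsubstituted phenyl, or a methoxy group in place of the hydroxyl, would tell the chain and the hydroxyl apart. Also open, on these data alone, is whether an amine or a carboxylic acid on that ring, or a still longer chain, would move the number further in this assay at this position.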